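The source may report more compounds than this note shows. Statements on the series, on what has been measured and on what is new or still open speak of the compounds shown alone.

In a functional assay on SK-MEL-147 cells (Homo sapiens) for cytotoxicity, read by MTT assay, with a stated time of 24 h (a higher number here means that more compound is needed for the effect, a lower number that less compound is needed), compound 1 (`CCOC(=O)c1cc([Se]c2ccccc2)c2cc(Br)ccc2n1`) gives 12400 nM and compound 2 (`CCOC(=O)c1cc(C#Cc2ccc(N)cc2)c2cc(OC)ccc2n1`) gives 8800 nM (two values within the usual scatter of each other). Compound 3 (`CCOC(=O)c1cc([Se]c2ccccc2)c2ccccc2n1`) has not yet been measured. It differs from compound 1 by a single change, hydrogen in place of bromo on an aromatic carbon. Within the data shown here, no measured pair shows the size of such a change, so no step beyond the scatter is expected in this assay in either direction. The estimated step (a 1.2-fold higher number from compound 1 to compound 3 (0.08 log units; within the scatter)) stays within that scatter. Compound 3 is expected at 15000 nM (estimated range 6000 nM to 35000 nM).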

Compound 3, half-maximal effective concentration: 86300 nM
Compound 3: middle estimate off by 5.8-fold (0.76 log units), on the low side, and the stated range ends below it.
By their numbers in this assay, from the lowest: compounds 2 and 1 (each within the scatter of the next); then compound 3.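

With hydrogen in place of bromo on an aromatic carbon, this assay shows a 7.0-fold higher number from compound 1 to compound 3 (0.84 log units; beyond the scatter), so more compound is needed for the effect once the bromo has left. Among these compounds, this is the first measured pair to size a change at this position, and it shows that the position is not indifferent to this exchange in this assay. No measurement at hand gives a reason for the step. Whether the bromo is special remains open, since the compounds shown do not tell how a chlorine, an amine or a carboxylic acid on this carbon would compare.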